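This account rests on a few compounds, and the source may have more. Where it says the series, first, only, none or still open, it means among the compounds named here.

Measured in a functional assay on HCT-116 cells (Homo sapiens) for inhibition, read by MTT assay, with a stated time of 96 h; a lower number here means a stronger inhibitor of growth, a higher number a weaker inhibitor of growth:

- compound 1 `CCCC(=O)SCCCCCCNC(=O)c1cc(-c2ccncc2)n[nH]1` gives 23500 nM
- compound 2 `O=C(NCCCCCCS)c1cc(-c2c[nH]c3ccccc23)n[nH]1` gives > 50000 nM
- compound 3 `CCCCCCCC/C=C\CCCCCCCC(=O)SCCCCCCNC(=O)c1cc(-c2ccncc2)n[nH]1` gives 39300 nM

The entry for compound 2 is a limit of the assay and not a number. Compound 1 at 23500 nM stands with compound 3 at 39300 nM, and these two true numbers lie within the usual scatter of each other.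

Compound 4 `CSCCCCCCNC(=O)c1cc(-c2ccncc2)n[nH]1` has methyl in place of propylcarbonyl on a sulfur and so has no carbonyl on that sulfur. Compound 3, at 39300 nM, keeps a carbonyl there with a different chain on it and stays within the scatter of compound 1. That comparison offers no measured guide to losing the carbonyl altogether, so the expectation is uncertain. A moderate move toward weaker growth inhibition seems most likely, and the assay may report only a limit. The expected change is a 2.1-fold higher number from compound 1 to compound 4 (0.33 log units; beyond the scatter) in this assay and it is only an estimate. For compound 4 the estimated value is 50000 nM, with an expected range from 20000 nM to 120000 nM.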

Compound 4, concentration for 50% growth inhibition: > 50000 nM
Compound 4 ended at the assay's limit; the forecaster's own chance of this, stated with the estimate: 60%; the middle value sits exactly at the limit.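

In this assay, methyl in place of propylcarbonyl on a sulfur gives an at least 2.1-fold higher number from compound 1 to compound 4 (0.32 log units; beyond the scatter), a step beyond the usual scatter. Within the data shown here, compound 1 and compound 3 both carry a carbonyl on this sulfur and lie within the scatter of each other, so this is the first sign that a change here can shift the number clearly. The entry for compound 4 is a limit of the assay and not a number, so the full size of the step remains unknown: the limit of > 50000 nM in this assay, at which 2 of the 4 values shown sit.

This change removes the carbonyl and shortens the group at the same time, and the compounds shown cannot separate those two differences. A plain butyl chain on the sulfur, which has no carbonyl, or an acetyl group, which keeps one on a shorter chain, would help to tell them apart.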